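The source may hold more compounds than are shown below. What is called first, only, known or untested is meant among the compounds shown, and "the series" means these compounds.

In a functional assay on HeLa cells (Homo sapiens) for cytotoxicity, read by WST assay, with a stated time of 48 h (on this read-out lower numbers stand for stronger inhibition and higher numbers for weaker inhibition), compound 3 `COc1cc(C(c2ccc(O)c(OC)c2)[C@H](C)[C@@H](C)CO)ccc1O` reports only a limit, > 100000 nM. Compound 1 `COc1cc(C(c2ccc(O)c(OC)c2)[C@@H](CO)C(C)C)ccc1O` likewise reports only a limit, > 100000 nM. Compound 2 `COc1cc(C(c2ccc(O)c(OC)c2)[C@H](CF)C(C)C)ccc1O` gives a number, 19000 nM. Compound 4 `COc1cc(C(c2ccc(O)c(OC)c2)[C@@H](CF)C(C)C)ccc1O` departs from compound 3 by one change: 1-(fluoromethyl)-2-methylpropyl in place of 2-(hydroxymethyl)-1-methylpropyl on a saturated chain carbon bound to two aromatic carbons. It thereby carries the 1-(fluoromethyl)-2-methylpropyl group also found in compound 2. Among the compounds with values here, two measured steps bear on this change: an at least 5.2-fold lower number from compound 1 to compound 2 (0.72 log units; beyond the scatter), and an at least 5.2-fold higher number from compound 2 to compound 3 (0.72 log units; beyond the scatter). Both lie beyond the scatter, yet each is bounded on one side by a limit, so their true size is open. A lower number of at least similar size is therefore expected, in the range of compound 2. The expected step is an at least 3.3-fold lower number from compound 3 to compound 4 (0.52 log units; beyond the scatter). For compound 4 the estimated value is 30000 nM, with an expected range from 10000 nM to 100000 nM.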

Compound 4, half-maximal inhibitory concentration: 41000 nM
Beside the measured number, compound 4's estimate is 1.4-fold (0.14 log units) below it, within the range that was stated.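

In this assay, the 1-(fluoromethyl)-2-methylpropyl group gives a readable number in its second drawn configuration too, with an at least 2.4-fold lower number from compound 3 to compound 4 (0.38 log units; beyond the scatter) and an at least 2.4-fold lower number from compound 1 to compound 4 (0.38 log units; beyond the scatter). The true size of those two steps stays bounded on one side only, as compounds 1 and 3 each report a limit: the limit of > 100000 nM in this assay, at which 2 of the 4 values shown sit. Configuration at this chain carbon also shifts the number modestly, with a 2.2-fold higher number from compound 2 to compound 4 (0.33 log units; beyond the scatter), and this step reads configuration alone: the fact that compounds 2 and 4 differ only in the configuration as drawn.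

The compounds shown leave open whether an amine or a chloro group in place of the hydroxy would move the number as fluoro does. They also leave open how far compounds 1 and 3 truly lie from the fluoro pair.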